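Halogen on the aromatic ring of the shared core: cytotoxicity notes

The source may report more compounds than this note shows. Statements on the series, on what has been measured and on what is new or still open speak of the compounds shown alone.

compound 1 `OCc1cn(Cc2ccccc2)c2ccccc12` — 14500 nM
compound 2 `OCc1cn(Cc2cccc(F)c2)c2ccccc12` — a limit of the assay only: > 31600 nM

For the measured compounds named here, compound 1 is the only compound that gives a number in an ADME assay on T29 cells (Homo sapiens) for cytotoxicity, read by sulforhodamine B assay, with a stated time of 3 days; on this read-out higher numbers stand for weaker inhibition and lower numbers for stronger inhibition; in this assay compound 1 gives 14500 nM, so it stands alone as the reference point of the series. Compound 2 gives only a limit of the assay, > 31600 nM. Going by the values given here, the single measured step, an at least 2.1-fold higher number from compound 1 to compound 2 (0.33 log units; beyond the scatter), is a fluoro in place of hydrogen on an aromatic carbon, runs toward weaker inhibition and ends at the limit of > 31600 nM in this assay, at which 1 of the 2 values shown sits.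

Compound 3 `OCc1cn(Cc2ccccc2Cl)c2ccccc12` differs from compound 1 by chloro in place of hydrogen on an aromatic carbon. This is the change that bears on it: a halogen entering on an aromatic carbon of the six-membered aromatic ring of carbon only, as in the measured step, here ortho to a large group. That step was at least modest and toward weaker inhibition, so for compound 3 a step of similar or larger size in the same direction is expected, with a real chance that this assay again reports only a limit. The expected value for compound 3 is 28000 nM, from 10000 nM to 70000 nM. This estimate corresponds to the expected step of a 1.9-fold higher number from compound 1 to compound 3 (0.29 log units; within the scatter).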

Compound 3, half-maximal inhibitory concentration: > 31600 nM
Compound 3: a limit, no number; the forecaster's own chance of this, stated with the estimate: 45%; middle value at least 1.1-fold (0.05 log units) away from the limit.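

The entering chloro group, here ortho to a large group, gives an at least 2.1-fold higher number from compound 1 to compound 3 (0.33 log units; beyond the scatter) in this assay. The direction seen with fluoro therefore holds for a second halogen and at a place ortho to a large group, and neither halogen step from compound 1 runs toward stronger inhibition. Both steps end at a limit and not at a number, so no order between fluoro and chloro can be read, and the series now stands mostly at that limit: the limit of > 31600 nM in this assay, at which 2 of the 3 values shown sit.

For the compounds shown here, compound 1 remains the only compound with a number, so it stays open whether any change on this ring can move the value toward stronger inhibition, and how far the two halogen compounds really lie from compound 1. From the compounds shown here alone, what an amine or a carboxylic acid on the same ring would give in this assay is also open, as is whether the halogen steps would hold with a longer chain in place of the hydroxymethyl group.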